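This account rests on a few compounds, and the source may have more. Where it says the series, first, only, none or still open, it means among the compounds named here.

Compound 1 `Cc1c(OCCCCOc2ccc(F)c(C(=O)O)c2)ccc(C(=O)CC(C)(C)C)c1O` was examined in an assay on HEK293 cells for positive allosteric modulation of metabotropic glutamate receptor 3 (Rattus norvegicus), read by thallium flux, with a stated time of 2.5 min (on this read-out lower numbers stand for an effect already at smaller amounts and higher numbers for an effect only at larger amounts of compound), and gave 258 nM. A close relative, compound 2 `Cc1c(OCCCCOc2ccc(C(=O)CC(C)(C)C)c(O)c2C)cccc1C(=O)O`, gave 300 nM in this assay; the step that separates them, a 1.2-fold higher number from compound 1 to compound 2 (0.07 log units; within the scatter), is within the scatter, so these two numbers cannot be told apart. A third compound, compound 3 `Cc1cc(C(=O)O)ccc1OCCCCOc1ccc(C(=O)C(C)C)c(O)c1C`, has no number in this assay: its entry reads "not determined" (no result reported). Among the two numbers that exist, compound 1 holds the lower one, with compound 2 as its only neighbour and at no meaningful distance from it.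

Compound 4 `Cc1c(OCCCCOc2ccc(F)c(C(=O)O)c2)ccc(C(=O)CC2CCCC2)c1O` differs from compound 1 in one place: cyclopentyl in place of tert-butyl on a saturated chain carbon bound to a carbonyl carbon. Among the compounds with values here, the one measured step, from compound 1 to compound 2, alters the carboxy-bearing aryl on the oxygen of the chain and leaves the ketone side untouched, so it does not speak to this change; no measured pair varies the group on the saturated chain carbon bound to the carbonyl carbon. With nothing in the data pointing either way, compound 4 is expected to sit close to compound 1, a step of a 1.2-fold higher number from compound 1 to compound 4 (0.07 log units; within the scatter) that lies within the scatter. In this assay compound 4 is therefore estimated at 300 nM, with a range from 90 nM to 1000 nM.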

Compound 4, half-maximal effective concentration: 2490 nM
Beside the measured number, compound 4's estimate is 8.3-fold (0.92 log units) below it, outside the stated range (above it).
By their numbers in this assay, from the lowest: compounds 1 and 2 (each within the scatter of the next); then compound 4.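

Within the data shown here, at the saturated chain carbon bound to a carbonyl carbon, the group matters in this assay: cyclopentyl in place of tert-butyl brings a 9.7-fold higher number from compound 1 to compound 4 (0.98 log units; beyond the scatter), whereas the only earlier step, on the carboxy-bearing aryl at the far end of the molecule, stayed within the scatter. This is the first sign among these compounds that the read-out responds to a change on the ketone side, and it comes from a swap between two groups made of carbon only, neither of which carries a hydrogen-bond donor, a hydrogen-bond acceptor or a net charge. Nothing measured here accounts for the size of this step.

The compounds shown leave open whether the higher number goes with the ring itself or with the loss of tert-butyl, which a cyclopropyl, a cyclohexyl or an open n-propyl chain at this place could separate. They also leave open whether the same swap would give a step of similar size on the 3-carboxy-2-methylphenyl partner of compound 2.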